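The compounds below may be only part of what the source reports. "The series", "measured", "known", "first", "only" and "open" are said of these compounds alone.

Measured so far: compound 2 `Cc1cn([C@@H]2O[C@H](CO[Si](C)(C)C(C)(C)C)[C@@]3(OS(=O)(=O)C=C3NC(=O)Nc3ccccc3)[C@H]2O[Si](C)(C)C(C)(C)C)c(=O)n(C)c1=O`, compound 3 `Cc1cn([C@@H]2O[C@H](CO[Si](C)(C)C(C)(C)C)[C@@]3(OS(=O)(=O)C=C3NC(=O)N(C(=O)Nc3ccccc3)c3ccccc3)[C@H]2O[Si](C)(C)C(C)(C)C)c(=O)n(C)c1=O` and compound 1 `Cc1cn([C@@H]2O[C@H](CO[Si](C)(C)C(C)(C)C)[C@@]3(OS(=O)(=O)C=C3NC(=O)NC(=O)c3ccccc3)[C@H]2O)c(=O)n(C)c1=O`. In an ADME assay on HEL cells (Homo sapiens) for cytotoxicity, with a stated time of 3 days (a lower number here means that less compound is tolerated, a higher number that more compound is tolerated), compound 2 gives 1300 nM. Compound 3 gives 13000 nM. Compound 1 gives 22000 nM.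

Compound 2 stands at the lowest number of the three, so less of it is tolerated than of either other compound; the gap to compound 3 and the larger gap to compound 1 are both beyond the scatter.

Compound 4 `CCOC(=O)NC(=O)NC1=CS(=O)(=O)O[C@@]12[C@@H](CO[Si](C)(C)C(C)(C)C)O[C@@H](n1cc(C)c(=O)n(C)c1=O)[C@@H]2O[Si](C)(C)C(C)(C)C` differs from compound 2 by ethoxycarbonyl in place of phenyl on an amide-type nitrogen. Among the compounds with values here, no measured step makes this exchange. Within the data shown here, the one step at the same nitrogen is a 10-fold higher number from compound 2 to compound 3 (1.00 log units; beyond the scatter), and that step adds a group to the nitrogen rather than exchanging one, so it bears only loosely on compound 4. Among the measured compounds shown here, compound 1 differs from compound 2 in two places at once and gives no single step, though its value shows that a change at this part of the molecule can go with a much higher number.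

On that indirect basis compound 4 is expected to give a somewhat higher number than compound 2, with wide uncertainty. The estimate for compound 4 is 5000 nM, in the range 1500 nM to 20000 nM. The step this expectation implies is a 3.8-fold higher number from compound 2 to compound 4 (0.59 log units; beyond the scatter).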

Compound 4, half-maximal cytotoxic concentration: 14000 nM
Compound 4: middle estimate off by 2.8-fold (0.45 log units), on the low side; the measured number falls inside the stated range.
By their numbers in this assay, from the lowest: compound 2; then compounds 3, 4 and 1 (each within the scatter of the next).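

In this assay, ethoxycarbonyl in place of phenyl on the amide-type nitrogen gives an 11-fold higher number from compound 2 to compound 4 (1.03 log units; beyond the scatter), so an exchange at this nitrogen is enough to leave the low number of compound 2 behind. Within the data shown here, the only earlier step at this nitrogen, a 10-fold higher number from compound 2 to compound 3 (1.00 log units; beyond the scatter), added phenylcarbamoyl and kept the phenyl; the new step shows that the six-membered aromatic ring of carbon can leave altogether and a group with no ring can take its place, with a step of the same order beyond the scatter. No data bearing on the cause of this step are available.

The compounds shown do not separate the loss of phenyl from the entry of ethoxycarbonyl, since both happen in one exchange; a plain ethyl group and a cyclohexyl ring on the same amide-type nitrogen would address that question. Also open, on these data alone, is how far the higher number in this assay extends to groups of another kind there, such as a carboxylic acid, an amine or a longer chain.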